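Aryl variation on the cyanopyridone ester core

The compounds below may be only part of what the source reports. "The series", "measured", "known", "first", "only" and "open" are said of these compounds alone.

Compound 2 `CCOC(=O)c1c(C)[nH]c(=O)c(C#N)c1-c1ccc(F)cc1` gives 15400 nM in a functional assay on A549 cells (Homo sapiens) for inhibition, read by MTT assay, with a stated time of 24 h; a lower number here means a stronger inhibitor, a higher number a weaker inhibitor; this value sits within the scatter of compound 1 `CCOC(=O)c1c(C)[nH]c(=O)c(C#N)c1-c1ccc(C)cc1`, which gives 15900 nM. Within the data shown here, the one measured step, a 1.0-fold lower number from compound 1 to compound 2 (0.01 log units; within the scatter), shows that changing the substituent on this aryl ring left the number unchanged. Compound 3 `CCOC(=O)c1c(C)[nH]c(=O)c(C#N)c1-c1ccccc1Cl` carries 2-chlorophenyl in place of 4-fluorophenyl on an aromatic carbon. Among the measured compounds shown here, no measured step covers a move of the halogen to a different position together with a chlorine for fluorine swap, so the expectation rests on the flat step seen so far. Compound 3 is therefore expected to give 15000 nM, range 5000 nM to 45000 nM, i.e. an expected step of a 1.0-fold lower number from compound 2 to compound 3 (0.01 log units; within the scatter).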

Compound 3, half-maximal inhibitory concentration: 25000 nM
Compound 3: middle estimate off by 1.7-fold (0.22 log units), on the low side, and the stated range covers the measured number.
By their numbers in this assay, from the lowest: compounds 2, 1 and 3 (each within the scatter of the next).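

With a 1.6-fold higher number from compound 2 to compound 3 (0.21 log units; within the scatter) and a 1.6-fold higher number from compound 1 to compound 3 (0.20 log units; within the scatter) in this assay the 2-chlorophenyl group stands level with both earlier aryl groups. The flat reading at this position therefore extends beyond the 4-fluorophenyl and 4-methylphenyl groups: a change of halogen and of its place on the aryl ring also stays within the scatter. No measurement on hand explains this flatness.

Still open, from the compounds shown here alone, is whether an amine or a carboxylic acid on the aryl ring would move the number beyond the scatter. A longer chain in place of the aryl ring is equally untested in the compounds shown.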